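Series notes: chain-carbon substituent swaps and microsomal half-life

The compounds below may be only part of what the source reports. "The series", "measured", "known", "first", "only" and "open" are said of these compounds alone.

Compound 2 `CC(C)C(CC(N)=O)c1ccc(-c2ccc3cccc(F)c3c2)[nH]c1=O` carries a carbamoylmethyl group on a saturated chain carbon bound to an aromatic carbon and a saturated chain carbon. In an ADME assay on microsomes from liver (Homo sapiens) for metabolic stability (on this read-out higher numbers stand for a longer-lived compound and lower numbers for a shorter-lived compound), compound 2 gives < 0.0667 h, which is a limit of the assay rather than a number. Compound 1 `CC(C)C(c1ncc[nH]1)c1ccc(-c2ccc3cccc(F)c3c2)[nH]c1=O` is the analogue with 1H-imidazol-2-yl at that carbon. In this assay compound 1 gives < 0.0667 h, again a limit. Among the compounds with values here, the one measured step, a step that the two limits leave unreadable from compound 1 to compound 2, therefore has no readable size; what the two values show is the limit of < 0.0667 h in this assay, at which 2 of the 2 values shown sit. Compound 3 `CC(C)C(c1cnc(N)s1)c1ccc(-c2ccc3cccc(F)c3c2)[nH]c1=O` is still unmeasured and differs from compound 2 by 2-amino-1,3-thiazol-5-yl in place of carbamoylmethyl on a saturated chain carbon bound to an aromatic carbon and a saturated chain carbon. Within the data shown here, no measured step bears directly on this change. With both measured compounds at the limit, compound 3 is expected to stay near the limit, and a step that the limit leaves unreadable from compound 2 to compound 3 is the expected step, with no size beyond the scatter claimed in either direction. The estimate for compound 3 is 0.04 h, within 0.01 h to 0.12 h.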

Compound 3, half-life: 0.178 h
Estimate against measurement, compound 3: 4.5-fold (0.65 log units) below, outside the stated range (above it).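

Notes on the result: at the saturated chain carbon bound to an aromatic carbon and a saturated chain carbon, the substituent can move the read-out in this assay clear of the limit. Replacing carbamoylmethyl with 2-amino-1,3-thiazol-5-yl gives an at least 2.6-fold higher number from compound 2 to compound 3 (0.42 log units; beyond the scatter), and replacing 1H-imidazol-2-yl with the same group gives an at least 2.6-fold higher number from compound 1 to compound 3 (0.42 log units; beyond the scatter). Both sizes are lower bounds only, and the step between the other two compounds stays unreadable, because of where their values stand: the limit of < 0.0667 h in this assay, at which 2 of the 3 values shown sit.

The compounds shown do not separate the amino group from the thiazole ring as the carrier of this change; a plain 1,3-thiazol-5-yl without the amine at this carbon would tell the two apart. Going by these compounds, how far compound 1 and compound 2 lie beyond their limit also stays open, and with it the full size of both steps.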